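Swapping Chlorine for Fluorine Beside the Sulfonamide

This account rests on a few compounds, and the source may have more. Where it says the series, first, only, none or still open, it means among the compounds named here.

Three measured compounds share one core and differ only in the ring that carries the sulfonamide. Compound 1 `COc1ccc(N2C[C@@H](C)N[C@@H](C)C2)cc1NS(=O)(=O)c1ccc(-n2cccn2)cc1` gives 15.9 nM in a functional assay for agonist activity at growth hormone secretagogue receptor type 1 (Homo sapiens), read by FLIPR; a lower number here means that less compound is needed, a higher number that more compound is needed for the effect. Compound 2 `COc1ccc(N2C[C@@H](C)N[C@@H](C)C2)cc1NS(=O)(=O)c1ccc(-c2cccs2)cc1` gives 3.98 nM in this assay, a step of a 4.0-fold lower number from compound 1 to compound 2 (0.60 log units; beyond the scatter). Compound 3 `COc1ccc(N2C[C@@H](C)N[C@@H](C)C2)cc1NS(=O)(=O)c1ccc(-c2cccs2)cc1Cl` gives 0.794 nM in this assay, the lowest of the three numbers, reached through the step of a 5.0-fold lower number from compound 2 to compound 3 (0.70 log units; beyond the scatter). The next compound, compound 4 `COc1ccc(N2C[C@@H](C)N[C@@H](C)C2)cc1NS(=O)(=O)c1ccc(-c2cccs2)cc1F`, changes one thing: fluoro in place of chloro on an aromatic carbon. Among the compounds with values here, only one measured step bears on this place, a 5.0-fold lower number from compound 2 to compound 3 (0.70 log units; beyond the scatter), which shows that putting chloro where hydrogen stood lowered the number clearly. Nothing measured here tells how fluoro compares with chloro at that spot. A small rise in the number is expected, with compound 4 placed between compound 2 at 3.98 nM and compound 3 at 0.794 nM. For compound 4 the expected value in this assay is 1.6 nM, within a range from 0.6 nM to 5 nM. The step this estimate means is a 2.0-fold higher number from compound 3 to compound 4 (0.30 log units; within the scatter), expected to remain modest.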

Compound 4, half-maximal effective concentration: 2 nM
Compound 4: the middle estimate sits 1.3-fold (0.10 log units) below what was measured, and the stated range covers the measured number.
By their numbers in this assay, from the lowest: compound 3; then compounds 4 and 2 (each within the scatter of the next); then compound 1.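

In this assay, within the data shown here, the step of a 2.5-fold higher number from compound 3 to compound 4 (0.40 log units; beyond the scatter) shows that the two halogens are not interchangeable on this aromatic carbon, something the earlier compounds could not show with chloro as the only halogen. The comparison with hydrogen, a 2.0-fold lower number from compound 2 to compound 4 (0.30 log units; within the scatter), lies within the scatter, so fluoro cannot be clearly told apart from hydrogen here, whereas chloro can. No measurement at hand explains why chloro and fluoro differ at this position.

On these data alone, whether bromo, methyl or a nitrile on the same carbon would give a number nearer to that of chloro or to that of hydrogen remains open. Also open, as far as these compounds go, is whether chloro and fluoro would differ in the same way with 1H-pyrazol-1-yl in place of thiophen-2-yl.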